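This account rests on a few compounds, and the source may have more. Where it says the series, first, only, none or still open, it means among the compounds named here.

Compound 1 `Cc1cc(Nc2cc(-c3ccccc3)[nH]n2)n2nc(SCc3cccc(Br)c3)nc2n1` gives > 50000 nM in an ADME assay on GES1 cells (Homo sapiens) for inhibition, read by MTT assay, with a stated time of 72 h (on this read-out higher numbers stand for weaker inhibition and lower numbers for stronger inhibition), which is a limit of the assay and not a number.
Compound 2 `COc1ccc(Cn2ccc(Nc3cc(C)nc4nc(SCc5ccc(Br)cc5)nn34)n2)cc1` gives > 50000 nM in this assay, again a limit.

For the measured compounds named here, compound 1 thus stands at the limit, and so does the only other value shown, so no ordering of the two can be made: the limit of > 50000 nM in this assay, at which 2 of the 2 values shown sit. Going by the values given here, no measured step exists in this set. Compound 3 `Cc1cc(Nc2cc(-c3ccccc3)[nH]n2)n2ncnc2n1` differs from compound 1 by hydrogen in place of (3-bromobenzyl)sulfanyl on an aromatic carbon. With both shown values at the limit, nothing in this assay points to a change beyond the scatter for this step. Compound 3 is therefore expected to sit at the limit once more, estimated at 50000 nM with a range of 20000 nM to 200000 nM, an expected step of a number no higher from compound 1 to compound 3 (the limit leaves the size open).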

Compound 3, half-maximal inhibitory concentration: > 50000 nM
Compound 3 ended at the assay's limit; the forecaster's own chance of this, stated with the estimate: 85%; the middle value sits exactly at the limit.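

No step from compound 1 to compound 3 can be read, as both values are limits and not numbers: the limit of > 50000 nM in this assay, at which 3 of the 3 values shown sit.

The compounds shown leave open whether hydrogen in place of (3-bromobenzyl)sulfanyl changes the read-out at all in this assay.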